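Replacing an Alkenyl Amide by a Sulfonamide: Expected Cytotoxicity

A few compounds are considered here, and "the series" means these few. Any claim that something is new, unique, unknown or untested is made for them only; others in the source may bear on it.

Two compounds have been measured so far in a functional assay on A-431 cells (Homo sapiens) for cytotoxicity, read by MTT assay, with a stated time of 48 h; a higher number here means a weaker inhibitor, a lower number a stronger inhibitor:

compound 1, `CCCCCCCCCCCCNC(=O)[C@@H](NC(=O)c1cccs1)[C@@H](C)O`, gives 16600 nM
compound 2, `CCCCCCCCCCCCNC(=O)[C@@H](NC(=O)/C=C/c1ccccc1)[C@@H](C)O`, gives > 200000 nM

The value of compound 2 is a limit of this assay, not a number; this is the limit of > 200000 nM in this assay, at which 1 of the 2 values shown sits. Compound 2 therefore stands at the weak end of what this assay can report.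

Compound 3, `CCCCCCCCCCCCNC(=O)[C@@H](NS(=O)(=O)c1ccc(C)cc1)[C@@H](C)O`, is not yet measured. It differs from compound 2 in one place: (4-methylphenyl)sulfonyl in place of (2-phenylethenyl)carbonyl on an amine nitrogen.

Among the measured compounds shown here, only one measured step exists, an at least 12-fold higher number from compound 1 to compound 2 (1.08 log units; beyond the scatter). That step swaps one group on a carbonyl carbon for another; it does not involve a sulfonyl group, so it does not bear directly on the change to compound 3. It shows only that what sits on that amide side of the shared core can move this assay a great deal.

For the measured compounds named here, with no step that addresses a sulfonamide, the expectation for compound 3 rests mainly on where compound 2 stands. Compound 3 is expected to give about 100000 nM, with a range from 20000 nM to 200000 nM. The expected step is an at least 2.0-fold lower number from compound 2 to compound 3 (0.30 log units; that floor lies within the scatter), and a limit rather than a number is quite possible.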

Compound 3, half-maximal inhibitory concentration: 25200 nM
Beside the measured number, compound 3's estimate is 4.0-fold (0.60 log units) above it; low and high end bracket the measured number.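

In this assay, the change on this amine nitrogen gives an at least 7.9-fold lower number from compound 2 to compound 3 (0.89 log units; beyond the scatter), so a sulfonyl link here can carry a value that the assay reports as a number, which (2-phenylethenyl)carbonyl did not. Compound 2 gives a limit and not a number, so the size of that step is only a minimum: the limit of > 200000 nM in this assay, at which 1 of the 3 values shown sits. Set against the other amide, the same group gives a 1.5-fold higher number from compound 1 to compound 3 (0.18 log units; within the scatter), so (4-methylphenyl)sulfonyl and (thiophen-2-yl)carbonyl cannot be told apart in this assay, and among the three groups now seen on this nitrogen, compound 2 is the one that stands apart.

As far as these compounds go, it remains open whether the sulfonyl link or the 4-methylphenyl ring on it accounts for the number, and a methylsulfonyl group or a thiophen-2-ylsulfonyl group on the same nitrogen would separate the two. Also open, from the compounds shown here alone, is how much the long chain on the other side of the shared core contributes, which a shorter chain in its place would test while the (4-methylphenyl)sulfonyl group stays fixed.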